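A few compounds are considered here, and "the series" means these few. Any claim that something is new, unique, unknown or untested is made for them only; others in the source may bear on it.

Compound 1 `Cc1ccc(N2CCn3c2n[nH]c(=O)c3=N)cc1` gives 38% in a functional assay on A549 cells (Homo sapiens) for antiproliferative activity, with a stated time of 72 h, tested at 50 ug/mL; a higher number here means a stronger effect of the compound at the concentration tested, a lower number a weaker effect. Compound 2 `O=c1[nH]nc2n(c1=O)CCN2c1cccc(Cl)c1` gives 0%. Compound 3 `O=c1[nH]nc2n(c1=O)CCN2c1ccc(Cl)cc1` gives 15%.

Compound 1 stands highest of the three numbers. The nearest is compound 3, whose value lies lower by a gap beyond the scatter; the furthest is compound 2, whose value is lower still, also beyond the scatter. Compound 4 `N=c1c(=O)[nH]nc2n1CCN2c1ccc(Cl)cc1` keeps the core of compound 1 and differs in one place: chloro in place of methyl on an aromatic carbon, on an aromatic carbon of a six-membered aromatic ring of carbon only, para to a large group. For the measured compounds named here, no measured pair isolates this change, so the size of the step is uncertain; a small downward step or none beyond the scatter is expected, a number 8 percentage points lower from compound 1 to compound 4 (within the scatter). Compound 4 is estimated at 30%, between 10% and 50%.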

Compound 4, a percentage reported as inhibition, at one concentration (the size of the read-out at that concentration, not a potency): 27%
Beside the measured number, compound 4's estimate is 3 percentage points above it; the measured number falls inside the stated range.
By their numbers in this assay, from the lowest: compound 2; then compound 3; then compound 4; then compound 1.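

In this assay, for the compounds shown here, chloro in place of methyl on an aromatic carbon, para to a large group, gives a number 11 percentage points lower from compound 1 to compound 4 (beyond the scatter), the first step that isolates a change at this position. The step is modest, and compound 4 keeps a measurable effect at 27%, so this position tolerates the swap with only a partial loss. As far as these compounds go, whether a methoxy group, an amine or a longer chain such as ethyl at the same place would raise or lower the number stays open. Nothing available explains the size of this step.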